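Isobutoxy replaces pyrrolidinyl on a shared core

The compounds below may be only part of what the source reports. "The series", "measured", "known", "first", "only" and "open" are said of these compounds alone.

The measured compounds are:
compound 1 `CC(C(=O)NCc1ccc(C(C)(C)C)nc1N1CCCC1)c1ccc(NS(C)(=O)=O)c(F)c1` — 1.2 nM
compound 2 `CCCOc1nc(C(C)(C)C)ccc1CNC(=O)C(C)c1ccc(NS(C)(=O)=O)c(F)c1` — 1.7 nM
compound 3 `CC(C)Oc1nc(C(C)(C)C)ccc1CNC(=O)C(C)c1ccc(NS(C)(=O)=O)c(F)c1` — 2.3 nM

All three were tested in an assay on cells for antagonist activity at transient receptor potential cation channel subfamily V member 1 (Homo sapiens), read by FLIPR and calcium flux, with a stated time of 6 min; on this read-out higher numbers stand for weaker inhibition and lower numbers for stronger inhibition. Compound 1 gives the lowest number of the three, yet its steps to both other compounds lie within the scatter: a 1.4-fold higher number from compound 1 to compound 2 (0.15 log units; within the scatter) and a 1.9-fold higher number from compound 1 to compound 3 (0.28 log units; within the scatter). Between the two alkoxy compounds the step is also within the scatter: a 1.4-fold higher number from compound 2 to compound 3 (0.13 log units; within the scatter). On these numbers the three compounds cannot be told apart.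

Compound 4 `CC(C)COc1nc(C(C)(C)C)ccc1CNC(=O)C(C)c1ccc(NS(C)(=O)=O)c(F)c1` differs from compound 1 in one place: isobutoxy in place of pyrrolidin-1-yl on an aromatic carbon. The two measured steps that bear on this are the ones in which an alkoxy group took the place of pyrrolidin-1-yl, from compound 1 to compound 2 and from compound 1 to compound 3, and both stayed within the scatter. A third alkoxy group of the same size is therefore expected to behave alike, with no step beyond the scatter in this assay, perhaps a slightly higher number in line with the propoxy and isopropoxy compounds.

Compound 4 is therefore estimated at 2.4 nM in this assay, within a range of 1 nM to 6 nM. This estimate corresponds to the step of a 2.0-fold higher number from compound 1 to compound 4 (0.30 log units; within the scatter), which is expected to stay within the scatter.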

Compound 4, inhibition constant: 0.6 nM
Compound 4: the middle estimate sits 4.0-fold (0.60 log units) above what was measured, outside the stated range (below it).
By their numbers in this assay, from the lowest: compounds 4, 1, 2 and 3 (each within the scatter of the next, the first and the last beyond it).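

The earlier compounds shown here gave no step beyond the scatter at this position, so the alkoxy groups there could not be told apart. In this assay the isobutoxy group now stands apart from the other two, with a 2.8-fold lower number from compound 2 to compound 4 (0.45 log units; beyond the scatter) when a methyl takes the place of a hydrogen on the propyl chain and a 3.8-fold lower number from compound 3 to compound 4 (0.58 log units; beyond the scatter) when isobutyl takes the place of isopropyl on the oxygen, so the group on the oxygen does register here, if only modestly. The exchange of the ring for the open chain remains unresolved, at a 2.0-fold lower number from compound 1 to compound 4 (0.30 log units; within the scatter) and so gives no order between isobutoxy and pyrrolidin-1-yl, and no evidence is at hand to explain any of these differences.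

The compounds shown leave open whether a longer chain such as butoxy, or a cyclopropylmethoxy group, would read like isobutoxy, and whether another ring amine such as piperidin-1-yl or morpholin-4-yl would read like pyrrolidin-1-yl. On these data alone, it also stays open whether the separation among the alkoxy groups would persist with trifluoromethyl in place of the tert-butyl group.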